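Methyl for Methoxy on the Shared Core

The source may hold more compounds than are shown below. What is called first, only, known or untested is meant among the compounds shown, and "the series" means these compounds.

Compound 1 `COc1ccc2c(c1)CC(NCC1CCN(CCNS(=O)(=O)c3cccc4ccccc34)CC1)CCC2`: 45 nM
Compound 2 `COc1cc2c(cc1OC)CC(NCC1CCN(CCNS(=O)(=O)c3cccc4ccccc34)CC1)CCC2`: 68 nM

In an assay on isolated protein for inhibition of Neuropeptide Y receptor type 5 (Homo sapiens) (a higher number here means a weaker inhibitor, a lower number a stronger inhibitor), compound 1 stands at one end of the two numbers shown, with compound 2 nearest, and the step of a 1.5-fold higher number from compound 1 to compound 2 (0.18 log units; within the scatter) lies within the scatter. Compound 3 `Cc1ccc2c(c1)CC(NCC1CCN(CCNS(=O)(=O)c3cccc4ccccc34)CC1)CCC2` differs from compound 1 by methyl in place of methoxy on an aromatic carbon. Going by the values given here, no measured step exchanges methoxy for methyl. Among the compounds with values here, the only step available concerns a methoxy on an aromatic carbon and stayed within the scatter, so no change beyond the scatter is expected from compound 1 to compound 3 in this assay. Compound 3 is therefore estimated at 60 nM, with a range of 20 nM to 180 nM. This means an expected step of a 1.3-fold higher number from compound 1 to compound 3 (0.12 log units; within the scatter).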

Compound 3, half-maximal inhibitory concentration: 72 nM
Beside the measured number, compound 3's estimate is 1.2-fold (0.08 log units) below it; low and high end bracket the measured number.
By their numbers in this assay, from the lowest: compounds 1, 2 and 3 (each within the scatter of the next).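

In this assay, methyl in place of methoxy on this aromatic carbon gives a 1.6-fold higher number from compound 1 to compound 3 (0.20 log units; within the scatter), so the oxygen of that methoxy is not needed to keep the number within the scatter. The earlier step only added a methoxy to the shared core, whereas this one replaces the methoxy that compound 1 already carries. No evidence on the reason for this result is at hand. Still open, as far as these compounds go, is whether a larger group on the same carbon, such as an amine, a carboxylic acid or a longer chain, would also stay within the scatter.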